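A few compounds are considered here, and "the series" means these few. Any claim that something is new, unique, unknown or untested is made for them only; others in the source may bear on it.

Compound 1, `N[C@H]1CC[C@H](Nc2c(C(=O)NCc3ccc(Cl)cc3)nc(Br)c3cccnc23)CC1`, carries no single number in a functional assay on MCF7 cells (Homo sapiens) for cytotoxicity, read by MTT assay, with a stated time of 72 h; on this read-out higher numbers stand for weaker inhibition and lower numbers for stronger inhibition; for compound 1 the entry reads "not determined" (no result reported). Compound 2, `CS(=O)(=O)NCCCN(c1nc(C(=O)NCc2ccc(F)cc2)c(O)c2ncccc12)S(C)(=O)=O`, reaches only a limit of the assay, and in this assay compound 2 gives > 20000 nM. The evidence so far amounts to the limit of > 20000 nM in this assay, at which 1 of the 2 values shown sits. Compound 3, `N[C@H]1CC[C@H](Nc2c(C(=O)NCc3ccc(F)cc3)nc(Br)c3cccnc23)CC1`, differs from compound 1 by fluoro in place of chloro on an aromatic carbon. For the measured compounds named here, with no measured step between these two compounds, the change is expected to move this assay by no more than the usual scatter, in either direction. For compound 3 the value in this assay is estimated at 5000 nM, within 500 nM to 20000 nM.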

Compound 3, half-maximal inhibitory concentration: 2000 nM
For compound 3 the middle estimate is 2.5-fold (0.40 log units) above the measured one, and the stated range covers the measured number.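

No new step can be read from compound 3, as compound 1, which differs from it in one place, carries no single number in this assay. From the compounds shown here alone, what the change from 4-chlorobenzyl to 4-fluorobenzyl does in this assay stays open.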